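The source may report more compounds than this note shows. Statements on the series, on what has been measured and on what is new or still open speak of the compounds shown alone.

Working notes on the series. Compound 1 `O=C(Nc1ccc(-c2noc(-c3cccc(NS(=O)(=O)c4ccc(C(F)(F)F)cc4)c3)n2)c(Cl)c1)c1cccnc1` is measured only as a limit in a functional assay on MDA-MB-231 cells (Homo sapiens) for antiproliferative activity, read by MTT assay, with a stated time of 72 h (a lower number here means a stronger inhibitor, a higher number a weaker inhibitor), where compound 1 gives > 10000 nM. Compound 2 `CC(=O)Nc1ccc(S(=O)(=O)Nc2cccc(-c3nc(-c4ccc(NC(=O)c5cccnc5)c(Cl)c4)no3)c2)cc1` gives 4500 nM in this assay. Compound 3 `COc1cc(-c2noc(-c3cccc(NS(=O)(=O)c4ccc(NC(C)=O)cc4)c3)n2)ccc1NC(=O)c1cccnc1` is also reported only as a limit, giving > 10000 nM. Among the measured compounds shown here, the single counted step, an at least 2.2-fold higher number from compound 2 to compound 3 (0.34 log units; beyond the scatter), concerns a different site and does not bear on the change considered here. Compound 4 `CCNC(=O)Nc1ccc(S(=O)(=O)Nc2cccc(-c3nc(-c4ccc(NC(=O)c5cccnc5)cc4Cl)no3)c2)cc1` differs from compound 1 by (ethylcarbamoyl)amino in place of trifluoromethyl on an aromatic carbon. For the measured compounds named here, no measured step matches this change; compound 2, carrying an acetamido on the same ring, at least lands below (the limit of > 10000 nM in this assay, at which 2 of the 3 values shown sit). On that basis compound 4 is expected to give 5000 nM, within 1500 nM to 20000 nM, so the step of an at least 2.0-fold lower number from compound 1 to compound 4 (0.30 log units; that floor lies within the scatter) is an estimate only.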

Compound 4, half-maximal inhibitory concentration: 3100 nM
Compound 4: the middle estimate sits 1.6-fold (0.21 log units) above what was measured; the measured number falls inside the stated range.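

On an aromatic carbon para to a large group, (ethylcarbamoyl)amino in place of trifluoromethyl gives an at least 3.2-fold lower number from compound 1 to compound 4 (0.50 log units; beyond the scatter) in this assay. Among the compounds shown here, this is the first step read at this site, and it gives a floor for the change, not its full size. Compound 1 is held only at a limit: the limit of > 10000 nM in this assay, at which 2 of the 4 values shown sit.

From the compounds shown here alone, whether an amine or a carboxylic acid at this position would lower the number as well stays open. So does the outcome of a longer chain in place of the ethyl.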